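Nitro in place of cyano: one expected step

The source may report more compounds than this note shows. Statements on the series, on what has been measured and on what is new or still open speak of the compounds shown alone.

Compound 1 `CC(O)(CSc1ccc(S(F)(F)(F)(F)F)cc1)C(=O)Nc1ccc(C#N)c(C(F)(F)F)c1` gives 16900 nM
Compound 2 `CC(O)(CSc1cccc(S(F)(F)(F)(F)F)c1)C(=O)Nc1ccc([N+](=O)[O-])c(C(F)(F)F)c1` gives 8600 nM
Compound 3 `CC(O)(CSc1cccc(S(F)(F)(F)(F)F)c1)C(=O)Nc1ccc(C#N)cc1C(F)(F)F` gives 17600 nM

In a functional assay on LNCaP cells (Homo sapiens) for antiproliferative activity, read by propidium iodide staining, with a stated time of 96 h (a higher number here means a weaker inhibitor, a lower number a stronger inhibitor), compound 3 stands within the scatter of compound 1 and beyond the scatter of compound 2, on the weaker side. Compound 4 `CC(O)(CSc1cccc(S(F)(F)(F)(F)F)c1)C(=O)Nc1ccc([N+](=O)[O-])cc1C(F)(F)F` has nitro in place of cyano on an aromatic carbon of compound 3 (nitro in place of cyano on an aromatic carbon). Among the compounds with values here, no pair of measured compounds shows this change alone. Compound 2 also carries nitro and gives 8600 nM but differs from compound 3 in more than one place, so it is only a loose guide. A small step toward a lower number, within the scatter, is therefore expected (a 1.6-fold lower number from compound 3 to compound 4 (0.20 log units; within the scatter)). The estimate for compound 4 is 11000 nM within an expected range of 5500 nM to 22000 nM for repeated measurements.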

Compound 4, half-maximal inhibitory concentration: 12700 nM
Beside the measured number, compound 4's estimate is 1.2-fold (0.06 log units) below it; the range from low to high includes it.
By their numbers in this assay, from the lowest: compounds 2, 4, 1 and 3 (each within the scatter of the next, the first and the last beyond it).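

Within the data shown here, measured directly for the first time, nitro in place of cyano on this aromatic carbon, para to a large group and meta to a trifluoromethyl group, gives a 1.4-fold lower number from compound 3 to compound 4 (0.14 log units; within the scatter) in this assay. Among these compounds, on this core, then, the two groups cannot be told apart in this read-out, and the earlier compounds, which differ in more than one place, could not show this. No measurement at hand explains the result.

Open, as far as these compounds go, is whether an amine or a carboxylic acid at this position would move the number beyond the scatter. Also open, from the compounds shown here alone, is whether the same change would read alike on the core of compound 1.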